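Side Chains on a Shared Core, One Still Unmeasured

The source may report more compounds than this note shows. Statements on the series, on what has been measured and on what is new or still open speak of the compounds shown alone.

In a functional assay on OVCAR-8 cells (Homo sapiens) for antiproliferative activity (on this read-out higher numbers stand for weaker inhibition and lower numbers for stronger inhibition), compound 1 `CNC(=O)C[C@@H]1C[C@@H](c2ccc(Cl)c(Cl)c2)[C@H](NC(=O)c2cc(-c3c(Cl)cnn3C)c(Cl)o2)CN1` gives 1130 nM, compound 2 `Cn1ncc(Cl)c1-c1cc(C(=O)N[C@@H]2CN[C@H](CCCO)C[C@H]2c2ccc(Cl)c(Cl)c2)oc1Cl` gives 600 nM and compound 3 `C=CC[C@@H]1C[C@@H](c2ccc(Cl)c(Cl)c2)[C@H](NC(=O)c2cc(-c3c(Cl)cnn3C)c(Cl)o2)CN1` gives 990 nM, so compound 3 lies within the usual scatter of both others. Compound 4 `Cn1ncc(Cl)c1-c1cc(C(=O)N[C@@H]2CN[C@H](CC(=O)NCCO)C[C@H]2c2ccc(Cl)c(Cl)c2)oc1Cl` has (2-hydroxyethyl)carbamoyl in place of vinyl on a saturated chain carbon bound to a saturated ring carbon. Compound 1 holds methylcarbamoyl there, so the closest measured comparison is a 1.1-fold lower number from compound 1 to compound 3 (0.06 log units; within the scatter). The other swaps there, a 1.7-fold higher number from compound 2 to compound 3 (0.22 log units; within the scatter) and a 1.9-fold lower number from compound 1 to compound 2 (0.27 log units; within the scatter), also stayed within the scatter. From the compounds shown here alone, no change beyond the scatter is therefore expected in this assay, and the direction stays open. The estimated step is a 1.0-fold higher number from compound 3 to compound 4 (0.00 log units; within the scatter). For compound 4 the estimate is 1000 nM, with an expected range of 450 nM to 2200 nM.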

Compound 4, half-maximal inhibitory concentration: 1450 nM
Compound 4: middle estimate off by 1.5-fold (0.16 log units), on the low side, and the stated range covers the measured number.
By their numbers in this assay, from the lowest: compounds 2, 3, 1 and 4 (each within the scatter of the next, the first and the last beyond it).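

In this assay, within the data shown here, placing (2-hydroxyethyl)carbamoyl on this saturated chain carbon gives the first step at this position that goes beyond the scatter, though only modestly: a 2.4-fold higher number from compound 2 to compound 4 (0.38 log units; beyond the scatter). The other two steps, a 1.5-fold higher number from compound 3 to compound 4 (0.17 log units; within the scatter) and a 1.3-fold higher number from compound 1 to compound 4 (0.11 log units; within the scatter), stay within the scatter, so the two amide side chains cannot be told apart here. Nothing available accounts for the gap between the hydroxyl-ended chain and the amide chain. From the compounds shown here alone, whether an amine or a carboxylic acid in place of these side chains would read closer to compound 2 or to compound 4 remains open.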